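Swapping Iodo for Propyl on the Anilino Ring

The compounds below may be only part of what the source reports. "The series", "measured", "known", "first", "only" and "open" are said of these compounds alone.

Measured compounds:
Compound 1 `O=C1C(Nc2ccc(I)cc2)=CC(=O)c2c1nc1n2[C@H]2OC[C@@H](O)[C@H]2OC1` gives 4010 nM.
Compound 2 `O=C1C=C(Nc2ccc(C(F)(F)F)cc2)C(=O)c2c1nc1n2[C@H]2OC[C@@H](O)[C@H]2OC1` reaches only a limit of the assay, > 8000 nM.
Compound 3 `O=C1C=C(N2CCCCC2)C(=O)c2c1nc1n2[C@H]2OC[C@@H](O)[C@H]2OC1` reaches only a limit of the assay, > 16000 nM.

All three were tested in a functional assay on HeLa cells (Homo sapiens) for inhibition, read by sulforhodamine B assay; on this read-out higher numbers stand for weaker inhibition and lower numbers for stronger inhibition. Compound 1 is the only one of them with an actual number; the values of compound 2 and compound 3 are limits, points at which the assay stops reporting a figure. Compound 1 therefore stands alone among the numbers shown, and nothing can be said about the size of the steps between the three.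

Compound 4 `CCCc1ccc(NC2=CC(=O)c3c(nc4n3[C@H]3OC[C@@H](O)[C@H]3OC4)C2=O)cc1` is the compound still to be tested. It keeps the whole core of compound 1 and differs in a single spot: propyl in place of iodo on an aromatic carbon. Within the data shown here, no two measured compounds differ from each other in only one place, so there is no measured step of this kind to lean on. Among the measured compounds shown here, with no precedent among the measured compounds, the expected step from compound 1 to compound 4 is small, a 1.2-fold higher number from compound 1 to compound 4 (0.10 log units; within the scatter), and not beyond the usual scatter in either direction. Compound 4 is thus estimated at 5000 nM, with a range from 1800 nM to 14000 nM. Two of the three measured compounds reached a limit, and compound 4 could do the same.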

Compound 4, half-maximal inhibitory concentration: 6030 nM
Estimate against measurement, compound 4: 1.2-fold (0.08 log units) below, and the stated range covers the measured number.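

Replacing 4-iodophenyl with 4-propylphenyl in this assay gives a 1.5-fold higher number from compound 1 to compound 4 (0.18 log units; within the scatter). Among these compounds, this is the first step in the set that can be read as a number, and it shows that at this position on the aromatic ring, a propyl chain of three carbons and a single iodine atom cannot be told apart in this read-out, even though the two groups share little beyond having no hydrogen-bond donors or acceptors. Compound 2, which carries trifluoromethyl at the same spot, reaches only a limit of the assay, so its step from compound 1 cannot be read and the comparison rests on propyl alone: the limit of > 8000 nM in this assay, at which 1 of the 4 values shown sits.

One step inside the scatter says nothing about why the two groups match, or how far this position would tolerate other groups. As far as these compounds go, whether a longer chain such as hexyl, a primary amine or a carboxylic acid at this spot would keep the number near that of compound 4 or move it clearly in either direction remains open.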